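Hydroxyazepane Sulfonamides and Liver Cell Toxicity

The source may hold more compounds than are shown below. What is called first, only, known or untested is meant among the compounds shown, and "the series" means these compounds.

Measured compounds:
compound 1 `CN1CCN(S(=O)(=O)c2cc(C(=O)Nc3ccc(F)c(Cl)c3)ccc2F)CC(O)C1` gives 31000 nM
compound 2 `O=C(Nc1ccc(F)c(Cl)c1)c1ccc(F)c(S(=O)(=O)N2CCCC(O)CC2)c1` gives 29000 nM

In an ADME assay on HepG2 2.2.15 cells (Homo sapiens) for cytotoxicity, read by luminescence, with a stated time of 3 days (on this read-out lower numbers stand for higher toxicity in this test and higher numbers for lower toxicity in this test), compound 2 holds the lowest of the two numbers, with compound 1 nearest, a gap that stays within the scatter. Compound 3 `CC1(O)CCCCN(S(=O)(=O)c2cc(C(=O)Nc3ccc(F)c(Cl)c3)ccc2F)C1` differs from compound 2 by 3-hydroxy-3-methylazepan-1-yl in place of 4-hydroxyazepan-1-yl on a sulfonyl sulfur. Within the data shown here, the one measured step, a 1.1-fold lower number from compound 1 to compound 2 (0.03 log units; within the scatter), is the only guide and showed no change beyond the scatter. Compound 3 is therefore expected to stay close to compound 2, a step of a 1.0-fold higher number from compound 2 to compound 3 (0.01 log units; within the scatter). The estimate for compound 3 is 30000 nM, with a range from 15000 nM to 60000 nM.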

Compound 3, half-maximal cytotoxic concentration: 10000 nM
Beside the measured number, compound 3's estimate is 3.0-fold (0.48 log units) above it; measured number outside the range, below it.
By their numbers in this assay, from the lowest: compound 3; then compounds 2 and 1 (each within the scatter of the next).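

In this assay, 3-hydroxy-3-methylazepan-1-yl on the sulfonyl sulfur gave a 2.9-fold lower number from compound 2 to compound 3 (0.46 log units; beyond the scatter) against 4-hydroxyazepan-1-yl, and a 3.1-fold lower number from compound 1 to compound 3 (0.49 log units; beyond the scatter) against 6-hydroxy-4-methyl-1,4-diazepan-1-yl. Unlike the earlier exchange, these steps show that a change of ring group at this place can move the number, here towards higher toxicity in this test. Nothing at hand accounts for the shift.

From the compounds shown here alone, what 3-hydroxyazepan-1-yl or 4-hydroxy-4-methylazepan-1-yl would give at this place stays open, and with it whether the step goes with the methyl or with the place of the hydroxy.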